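Ring Size on the Chain in a Three-Compound Series

The source may report more compounds than this note shows. Statements on the series, on what has been measured and on what is new or still open speak of the compounds shown alone.

Measured so far:
compound 1, `COc1ccc(-n2nc(C(=O)Nc3ccc(Oc4ccnc5cc(OCCCN6CCCC6)c(OC)cc45)c(F)c3)c(C)cc2=O)cc1`, 1290 nM
compound 2, `COc1ccc(-n2nc(C(=O)Nc3ccc(Oc4ccnc5cc(OCCCN6CCCCC6)c(OC)cc45)c(F)c3)c(C)cc2=O)cc1`, 330 nM
compound 3, `COc1cc2c(Oc3ccc(NC(=O)c4nn(-c5ccc(Cl)cc5)c(=O)cc4C)cc3F)ccnc2cc1OCCCN1CCCC1`, 150 nM

All three compounds were tested in a functional assay on MKN-45 cells (Homo sapiens) for inhibition, read by MTT assay, with a stated time of 72 h; a higher number here means a weaker inhibitor, a lower number a stronger inhibitor. Compound 3 gives the lowest number of the three, and its separation from both others is beyond the scatter. Two single changes connect the measured compounds. From compound 1 to compound 2 the change is piperidin-1-yl in place of pyrrolidin-1-yl on a saturated chain carbon, three bonds along the chain from an oxygen on an aromatic ring, and it gave a 3.9-fold lower number from compound 1 to compound 2 (0.59 log units; beyond the scatter). From compound 1 to compound 3 the cores differ by chloro in place of methoxy on an aromatic carbon, which gave an 8.6-fold lower number from compound 1 to compound 3 (0.93 log units; beyond the scatter).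

Compound 4, `COc1cc2c(Oc3ccc(NC(=O)c4nn(-c5ccc(Cl)cc5)c(=O)cc4C)cc3F)ccnc2cc1OCCCN1CCCCC1`, has not yet been measured in this assay. It differs from compound 3 by piperidin-1-yl in place of pyrrolidin-1-yl on a saturated chain carbon, three bonds along the chain from an oxygen on an aromatic ring. This is the same change as that from compound 1 to compound 2, made on the core of compound 3 instead of the core of compound 1. Because a 3.9-fold lower number from compound 1 to compound 2 (0.59 log units; beyond the scatter) was beyond the scatter, a step of similar direction and size is expected here, a 3.3-fold lower number from compound 3 to compound 4 (0.52 log units; beyond the scatter), although it rests on a single earlier case. Compound 4 is therefore estimated at 45 nM, with a plausible range from 15 nM to 130 nM.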

Compound 4, half-maximal inhibitory concentration: 230 nM
Beside the measured number, compound 4's estimate is 5.1-fold (0.71 log units) below it; the whole stated range lies below it.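

In this assay, piperidin-1-yl in place of pyrrolidin-1-yl on the core of compound 3 gave a 1.5-fold higher number from compound 3 to compound 4 (0.19 log units; within the scatter), so the step seen on the core of compound 1 did not carry over: the same change on two cores in this assay, a 3.9-fold lower number (0.59 log units; beyond the scatter) from compound 1 to compound 2 and a 1.5-fold higher number (0.19 log units; within the scatter) from compound 3 to compound 4, 6.0-fold (0.78 log units) apart, beyond the scatter of two such steps Seen from the other side, chloro in place of methoxy with piperidin-1-yl on the chain gave a 1.4-fold lower number from compound 2 to compound 4 (0.16 log units; within the scatter), and this step also failed to match its earlier counterpart: the same change on two cores in this assay, an 8.6-fold lower number (0.93 log units; beyond the scatter) from compound 1 to compound 3 and a 1.4-fold lower number (0.16 log units; within the scatter) from compound 2 to compound 4, 6.0-fold (0.78 log units) apart, beyond the scatter of two such steps The two changes therefore do not add up in this series, since each step is beyond the scatter only when it starts from compound 1, but these four compounds form a single set, and they do not show why this happens or whether it would recur on any other core.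

The compounds shown leave open whether the same mismatch would appear with morpholin-4-yl at the end of the chain, or with a longer chain. They also leave open how a fluoro group in place of chloro would behave with either ring on the chain.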